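This account rests on a few compounds, and the source may have more. Where it says the series, first, only, none or still open, it means among the compounds named here.

Compound 1 `CC(C)COc1cccc2occ(Cc3coc4ccccc4c3=O)c(=O)c12` and compound 2 `O=c1c(Cc2coc3cccc(O)c3c2=O)coc2ccccc12` share a core and differ only at one oxygen on an aromatic ring. In a functional assay on PC-3 cells (Homo sapiens) for antiproliferative activity, read by XTT assay (on this read-out lower numbers stand for stronger inhibition and higher numbers for weaker inhibition), compound 1 gives 1720 nM, while compound 2 gives 5950 nM; the step of a 3.5-fold higher number from compound 1 to compound 2 (0.54 log units; beyond the scatter) is the only one measured so far. For the measured compounds named here, compound 2 therefore stands at the highest of the two numbers on record, with compound 1 as its only neighbour.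

Compound 3 `COc1cccc2occ(Cc3coc4ccccc4c3=O)c(=O)c12` is reached from compound 2 by the change (methyl in place of hydrogen on an oxygen on an aromatic ring), that is, hydroxy to methoxy. This change runs opposite to the step of a 3.5-fold higher number from compound 1 to compound 2 (0.54 log units; beyond the scatter), which removed an alkyl group from the same oxygen, though the group restored here is smaller. A lower number is expected for compound 3, and the step of a 2.0-fold lower number from compound 2 to compound 3 (0.30 log units; within the scatter) is estimated to be modest but beyond the scatter. For compound 3 the expected value is 3000 nM, with a range from 1200 nM to 7000 nM.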

Compound 3, half-maximal inhibitory concentration: 3490 nM
The estimate for compound 3 lay 1.2-fold (0.07 log units) below the measured number, within the range that was stated.
By their numbers in this assay, from the lowest: compound 1; then compounds 3 and 2 (each within the scatter of the next).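

At this oxygen on an aromatic ring, hydroxy to methoxy gives no readable difference in this assay: the step of a 1.7-fold lower number from compound 2 to compound 3 (0.23 log units; within the scatter) stays inside the scatter, so a methyl alone does not reproduce what the isobutyl group gives. Compound 1 still stands apart, with the step of a 2.0-fold higher number from compound 1 to compound 3 (0.31 log units; beyond the scatter) lying beyond the scatter, so among these three compounds only the isobutyl group separates from the others. No measurement on record speaks to why this is so.

The compounds leave open whether the lower number of compound 1 goes with the length of the chain or with its branch, which a straight butyl chain or a longer chain on this oxygen would help to separate. As far as these compounds go, how an amine or a carboxylic acid at the end of such a chain would read also remains open.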